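A few compounds are considered here, and "the series" means these few. Any claim that something is new, unique, unknown or untested is made for them only; others in the source may bear on it.

Compound 2, `COc1ccc(/C=C/C2CC=CC(=O)N2)cc1`, is the point of departure. In a functional assay on 786-0 cells (Homo sapiens) for inhibition, read by sulforhodamine B assay, with a stated time of 48 h (on this read-out higher numbers stand for weaker inhibition of growth and lower numbers for stronger inhibition of growth), compound 2 gives > 1090 uM, which is a limit of the assay and not a number. Compound 1, `O=C1C=CCC(/C=C/c2ccccc2)N1`, the same core lacking the methoxy group, likewise stops at a limit: in this assay compound 1 gives > 1250 uM, again a limit rather than a number. The step that the two limits leave unreadable from compound 1 to compound 2 is therefore unreadable, since both values sit at limits (the limit of > 1090 uM in this assay, at which 1 of the 2 values shown sits, and (the limit of > 1250 uM in this assay, at which 1 of the 2 values shown sits)). Compound 3, `COc1ccc(/C=C/C2CC=CC(=O)N2)c(OC)c1`, carries the change (methoxy in place of hydrogen on an aromatic carbon). For the measured compounds named here, the only measured step that bears on a methoxy entering is the step from compound 1 to compound 2, and it tells nothing about size or direction. The expectation is therefore that compound 3 shows a step that the limit leaves unreadable from compound 2 to compound 3 that stays within the scatter. Compound 3 is expected to give 1500 uM, between 400 uM and 6000 uM, most likely once more reported only as a limit.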

Compound 3, concentration for growth inhibition (reported as GI): > 964 uM
Compound 3: no number, only a limit; the forecaster's own chance of this, stated with the estimate: 85%; the middle value is on the limit's open side.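

Compound 2 and compound 3 are each reported only as a limit in this assay, so the step between them cannot be read. The compounds shown leave open whether a methoxy group entering changes growth inhibition at all, and in which direction.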